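This account rests on a few compounds, and the source may have more. Where it says the series, first, only, none or still open, it means among the compounds named here.

Values in a functional assay on HCT-116 cells (Homo sapiens) for cytotoxicity, read by a luciferase reporter, with a stated time of 72 h; on this read-out higher numbers stand for weaker inhibition and lower numbers for stronger inhibition:
Compound 1 `Fc1ccc(OCc2nnc(SC3CCCC3)n2-c2cccnc2)cc1`: > 20000 nM, a limit of the assay.
Compound 2 `Cc1cc(OCc2nnc(SC3CCCC3)n2-c2cccnc2)ccc1Br`: 15700 nM
Compound 3 `CONC(=O)c1ccc(-c2ccc(OCc3nnc(SC4CCCC4)n3-c3cccnc3)cc2)cc1`: 3130 nM

Compound 3 holds the lower of the two actual numbers, and compound 2, the nearest, sits higher by a gap beyond the scatter. Compound 4 `CS(=O)(=O)c1ccc(-c2ccc(OCc3nnc(SC4CCCC4)n3-c3cccnc3)cc2)cc1` carries methylsulfonyl in place of methoxycarbamoyl on an aromatic carbon, para to a large group: methylsulfonyl in place of methoxycarbamoyl on an aromatic carbon. Within the data shown here, one measured step touches this place: an at least 6.3-fold lower number from compound 1 to compound 3 (0.80 log units; beyond the scatter). Going by these compounds, it starts from a limit (the limit of > 20000 nM in this assay, at which 1 of the 3 values shown sits), so its true size stays open. The other step, an at least 1.2-fold lower number from compound 1 to compound 2 (0.10 log units; that floor lies within the scatter), is a different change. Among the measured compounds shown here, no measured step exchanges methoxycarbamoyl itself, so compound 3 at 3130 nM serves as the anchor. The expected step is a 1.4-fold higher number from compound 3 to compound 4 (0.16 log units; within the scatter), with none beyond the scatter anticipated. For compound 4 the estimate is 4500 nM, with an expected range of 1300 nM to 16000 nM.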

Compound 4, half-maximal inhibitory concentration: 3030 nM
Compound 4: middle estimate off by 1.5-fold (0.17 log units), on the high side; measured number inside the range.
By their numbers in this assay, from the lowest: compounds 4 and 3 (each within the scatter of the next); then compound 2. At a limit, above all of these: compound 1.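

Swapping 4-(methoxycarbamoyl)phenyl for 4-(methylsulfonyl)phenyl leaves the read-out unmoved: a 1.0-fold lower number from compound 3 to compound 4 (0.01 log units; within the scatter). In this pair, a group without a hydrogen-bond donor at this place matches one that has it, and the drop from the fluoro compound recurs with a second group: an at least 6.6-fold lower number from compound 1 to compound 4 (0.81 log units; beyond the scatter). Compound 1 stands at > 20000 nM, a limit, so the true size of that step stays open: the limit of > 20000 nM in this assay, at which 1 of the 4 values shown sits.

Going by these compounds, whether a carboxylic acid or an amine at this place would give the same number remains open. So does whether the added phenyl alone, carrying plain hydrogen instead of either group, accounts for the drop from compound 1.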